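The source may hold more compounds than are shown below. What is called first, only, known or untested is meant among the compounds shown, and "the series" means these compounds.

Among the compounds with values here, compound 3 `CC1=NC(C)=C([N+](=O)[O-])C(c2ccncc2)/C1=C(\O)OC(C)(C)C` gives 2820 nM in a functional assay (cardiac atrium) for agonist activity, with Cavia porcellus as the target (on this read-out lower numbers stand for an effect already at smaller amounts and higher numbers for an effect only at larger amounts of compound), the second highest of the three numbers measured so far. Compound 2 `CC1=NC(C)=C([N+](=O)[O-])C(c2cccnc2)/C1=C(\O)OC1CCCCC1` gives 2760 nM, and the two values sit within the usual scatter of each other. Within the data shown here, compound 1 `CO/C(O)=C1\C(C)=NC(C)=C([N+](=O)[O-])C1c1ccncc1` gives 48500 nM, and the step of a 17-fold lower number from compound 1 to compound 3 (1.24 log units; beyond the scatter) is the only measured step that touches the group on this oxygen. Compound 4 `CC1=NC(C)=C([N+](=O)[O-])C(c2ccncc2)/C1=C(\O)OC1CCCCC1` differs from compound 3 in one place: cyclohexyl in place of tert-butyl on an oxygen on an unsaturated carbon. Among the measured compounds shown here, the methyl-to-tert-butyl step shows that a change at this oxygen can move the number a long way, but no measured step covers the tert-butyl-to-cyclohexyl exchange itself. For compound 4 the expected step of a 1.4-fold lower number from compound 3 to compound 4 (0.15 log units; within the scatter) is therefore small, at most a modest lowering. Compound 4 is estimated at 2000 nM, with a range from 700 nM to 6000 nM.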

Compound 4, half-maximal effective concentration: 4940 nM
Compound 4: middle estimate off by 2.5-fold (0.39 log units), on the low side; measured number inside the range.
By their numbers in this assay, from the lowest: compounds 2, 3 and 4 (each within the scatter of the next); then compound 1.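

In this assay, within the data shown here, a 1.8-fold higher number from compound 3 to compound 4 (0.24 log units; within the scatter) leaves cyclohexyl and tert-butyl on this oxygen unresolved, so the ring adds no readable change over the open branched group. a 9.8-fold lower number from compound 1 to compound 4 (0.99 log units; beyond the scatter) puts cyclohexyl, like tert-butyl, clearly apart from methyl. a 1.8-fold higher number from compound 2 to compound 4 (0.25 log units; within the scatter) is the first reading of pyridin-4-yl against pyridin-3-yl on the saturated ring carbon, and it too stays unresolved.

As far as these compounds go, whether an aminoethyl group or a longer chain such as n-hexyl on this oxygen would hold or shift the number remains open. Nothing at hand explains any of these steps.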